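Adding a bromohydroxyphenyl group to an inactive furan compound

The compounds below may be only part of what the source reports. "The series", "measured", "known", "first", "only" and "open" are said of these compounds alone.

Measured so far in a functional assay on EC9706 cells (Homo sapiens) for antiproliferative activity, read by MTT assay, with a stated time of 72 h; a lower number here means a stronger inhibitor, a higher number a weaker inhibitor
- compound 1 `C/C(=N\NC(=O)c1cccc(S(=O)(=O)N2CCOCC2)c1)c1ccc(O)cc1` gives 71400 nM
- compound 2 `C/C(=N\NC(=O)c1cccc(S(=O)(=O)N2CCOCC2)c1)c1cc(Br)ccc1O` gives 24700 nM
- compound 3 `O=C(N/N=C/c1ccco1)c1cccc(S(=O)(=O)N2CCOCC2)c1` gives > 100000 nM as a limit

Compound 3 stands at the limit of > 100000 nM in this assay, at which 1 of the 3 values shown sits, and so has a limit, not a number. The change to compound 4 `O=C(N/N=C/c1cc(Br)ccc1O)c1cccc(S(=O)(=O)N2CCOCC2)c1` is 5-bromo-2-hydroxyphenyl in place of furan-2-yl on a carbon with a double bond to nitrogen, a 5-bromo-2-hydroxyphenyl in place of furan-2-yl on a carbon with a double bond to nitrogen. Going by the values given here, the one measured step that bears on it, a 2.9-fold lower number from compound 1 to compound 2 (0.46 log units; beyond the scatter), is modest but beyond the scatter, and it brings in the same 5-bromo-2-hydroxyphenyl in place of 4-hydroxyphenyl. Compound 2, which carries this group, gives 24700 nM in this assay and is the nearest guide. The expected step, an at least 3.3-fold lower number from compound 3 to compound 4 (0.52 log units; beyond the scatter), points to a lower number, with its size uncertain. For compound 4 the estimate is 30000 nM, with an expected range of 10000 nM to 80000 nM.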

Compound 4, half-maximal inhibitory concentration: 29700 nM
For compound 4 the middle estimate is 1.0-fold (0.00 log units) above the measured one; the measured number falls inside the stated range.
By their numbers in this assay, from the lowest: compounds 2 and 4 (each within the scatter of the next); then compound 1. At a limit, above all of these: compound 3.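

In this assay there is an at least 3.3-fold lower number from compound 3 to compound 4 (0.52 log units; beyond the scatter), so swapping furan-2-yl for 5-bromo-2-hydroxyphenyl on this carbon brings a measurable number out of an inactive compound. The same group also lowered the number against 4-hydroxyphenyl, so it now does so against two different partners, and compound 2 and compound 4 lie within the scatter of each other. The true step may be larger, as compound 3 has only a limit, not a number: the limit of > 100000 nM in this assay, at which 1 of the 4 values shown sits.

The compounds shown leave open whether the bromine or the hydroxyl carries this step. A plain phenyl, or a chlorine in place of the bromine, could separate the two.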